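Swapping Chloro for Bromo on an Aromatic Ring

This account rests on a few compounds, and the source may have more. Where it says the series, first, only, none or still open, it means among the compounds named here.

Compounds measured so far:
- Compound 1 `CCOC(=O)c1nn(-c2ccc(Cl)cc2)c(-c2ccc(Br)cc2)c1CNC(C)(C)C`: > 511000 nM; > 476000 nM (2 entries)
- Compound 2 `CC(C)(C)NCc1c(C(=O)O)nn(-c2ccc(Cl)cc2)c1-c1ccc(Cl)cc1`: 290000 nM

Both were tested in a functional assay on K562 cells (Homo sapiens) for inhibition, read by sulforhodamine B assay, with a stated time of 48 h; on this read-out lower numbers stand for stronger inhibition of growth and higher numbers for weaker inhibition of growth. Compound 1 gives only limits of the assay, not numbers. For the measured compounds named here, compound 2, at 290000 nM, therefore holds the only actual number in this assay.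

Compound 3 `CC(C)(C)NCc1c(C(=O)O)nn(-c2ccc(Cl)cc2)c1-c1ccc(Br)cc1` differs from compound 2 in one place: bromo in place of chloro on an aromatic carbon. This is bromo in place of chloro on an aromatic carbon, para to a large group. Going by the values given here, no measured pair tests this swap, so no step beyond the usual scatter is expected in this assay, in either direction. The expected change is a 1.1-fold lower number from compound 2 to compound 3 (0.03 log units; within the scatter). For compound 3 the estimated value is 270000 nM, with an expected range of 140000 nM to 500000 nM.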

Compound 3, concentration for 50% growth inhibition: 297000 nM
The estimate for compound 3 lay 1.1-fold (0.04 log units) below the measured number; the measured number falls inside the stated range.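

In this assay this pair gives the only measured test of the swap from 4-chlorophenyl to 4-bromophenyl, and the result is a 1.0-fold higher number from compound 2 to compound 3 (0.01 log units; within the scatter). At this place on the aromatic ring, chloro and bromo therefore cannot be told apart in this read-out. Nothing measured here offers an explanation for this result.

On these data alone, it remains open whether a different group at the same place, such as a nitrile or a methoxy group, would give a number outside the scatter. As far as these compounds go, whether the same swap behaves alike with the ethyl ester in place of the carboxylic acid also stays unknown.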